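Amide substituent swap on the shared core, compound 1 to 4

This account rests on a few compounds, and the source may have more. Where it says the series, first, only, none or still open, it means among the compounds named here.

Compound 1 `O=C(/C=C/c1coc2cc(O)ccc2c1=O)NCc1ccc(F)cc1` is the starting point. Going by the values given here, in a functional assay on A549 cells (Homo sapiens) for inhibition, read by MTT assay, with a stated time of 48 h (a higher number here means a weaker inhibitor, a lower number a stronger inhibitor), compound 1 reaches only the limit of the assay, > 100000 nM, a limit and not a number; it is the one compound sitting at the limit of > 100000 nM in this assay, at which 1 of the 3 values shown sits. The two compounds that do give numbers carry a differently substituted core: compound 2 `COc1ccc2c(=O)c(/C=C/C(=O)Nc3ccc(C)cc3)coc2c1` gives 17500 nM in this assay, and compound 3 `COc1ccc2c(=O)c(/C=C/C(=O)Nc3ccccc3)coc2c1` gives 51000 nM. Among the compounds with values here, the single step among them, a 2.9-fold higher number from compound 2 to compound 3 (0.46 log units; beyond the scatter), shows a modest loss when the methyl is removed. Compound 4 `Cc1ccccc1NC(=O)/C=C/c1coc2cc(O)ccc2c1=O` differs from compound 1 by 2-methylphenyl in place of 4-fluorobenzyl on an amide-type nitrogen. Within the data shown here, no measured step covers this exact change; the step from compound 2 to compound 3 bears on it only in that a methyl on an aromatic carbon of the group on the amide-type nitrogen went with a lower number. Because compound 1 gives only > 100000 nM, the step cannot be anchored. Compound 4 is expected to reach a measurable number, the estimated step being an at least 2.8-fold lower number from compound 1 to compound 4 (0.45 log units; beyond the scatter). Compound 4 is therefore estimated at 35000 nM, within 10000 nM to 100000 nM.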

Compound 4, half-maximal inhibitory concentration: > 100000 nM
Compound 4 ended at the assay's limit; the forecaster's own chance of this, stated with the estimate: 35%; middle value at least 2.8-fold (0.45 log units) away from the limit.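

Compound 1 and compound 4 both sit at a limit and not at a number, so no step between them can be read: the limit of > 100000 nM in this assay, at which 2 of the 4 values shown sit.

Left open is whether 2-methylphenyl in place of 4-fluorobenzyl on an amide-type nitrogen changes inhibition at all on this shared core.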